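A few compounds are considered here, and "the series" means these few. Any claim that something is new, unique, unknown or untested is made for them only; others in the source may bear on it.

Going by the values given here, compound 2, `C[C@@H]1CCCN1c1c(C#N)c2c(N)ncnc2n1C`, gives 11 nM in an assay on isolated protein for inhibition of Leucine-rich repeat serine/threonine-protein kinase 2 variant G2019S (Homo sapiens), read by TR-FRET and LanthaScreen, with stated times of 50 min and 30 min, in the presence of a further agent that is not named here (a higher number here means a weaker inhibitor, a lower number a stronger inhibitor), the lower of the two numbers measured so far. Among the compounds with values here, compound 1, `CN(C)c1c(C#N)c2c(N)ncnc2n1C`, gives 3760 nM in this assay, and the one measured step, a 340-fold lower number from compound 1 to compound 2 (2.53 log units; beyond the scatter), is large and well beyond the scatter. Compound 3, `Cc1n[nH]cc1Nc1nc(N)c2c(C#N)c(N3CCC[C@H]3C)n(C)c2n1`, differs from compound 2 by (3-methyl-1H-pyrazol-4-yl)amino in place of hydrogen on an aromatic carbon. Within the data shown here, no measured step touches this position or this kind of group: the step from compound 1 to compound 2 concerns a different part of the shared core, so it gives no direct guide to the size or direction of the change from compound 2 to compound 3. The expectation for compound 3 therefore rests on compound 2 alone and is uncertain; it is estimated that compound 3 gives about 5 nM in this assay, within a range of 1 nM to 30 nM, a step of a 2.2-fold lower number from compound 2 to compound 3 (0.34 log units; beyond the scatter) that is expected to stay near or slightly below the scatter.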

Compound 3, half-maximal inhibitory concentration: 27 nM
Beside the measured number, compound 3's estimate is 5.4-fold (0.73 log units) below it; measured number inside the range.
By their numbers in this assay, from the lowest: compound 2; then compound 3; then compound 1.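

In this assay, (3-methyl-1H-pyrazol-4-yl)amino in place of hydrogen on the aromatic carbon between two ring nitrogen atoms gives a 2.5-fold higher number from compound 2 to compound 3 (0.39 log units; beyond the scatter), a modest change that is nonetheless beyond the scatter. Going by these compounds alone, the earlier compounds carry only hydrogen here, so this is the first reading of the position: it can hold a group of 7 heavy atoms with a five-membered aromatic ring, at a modest rise in the number. No measurement given here bears on what lies behind this step.

The compounds shown leave open whether a simple amino group, a methylamino group or a methoxy group at this carbon would give a lower or a higher number. They also leave open which part of the entering group, the amine link, the pyrazole ring or its methyl, accounts for the step.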